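The compounds below may be only part of what the source reports. "The series", "measured", "known", "first", "only" and "open" are said of these compounds alone.

For the measured compounds named here, in a functional assay on MCF7 cells (Homo sapiens) for antiproliferative activity (on this read-out higher numbers stand for weaker inhibition and lower numbers for stronger inhibition), compound 1 (`O=C(Nc1ccc(O)c2c(=O)cc(-c3ccccc3Cl)oc12)c1ccc(Cl)c(Cl)c1`) gives 15000 nM, the higher of the two numbers so far, and compound 2 (`C[C@H](NC(=O)OC(C)(C)C)C(=O)Nc1ccc(O)c2c(=O)cc(-c3ccccc3Cl)oc12`) gives 5500 nM. Compound 3 (`CS(=O)(=O)Nc1ccc(O)c2c(=O)cc(-c3ccccc3Cl)oc12`) is unmeasured. It differs from compound 1 as follows: methylsulfonyl in place of (3,4-dichlorophenyl)carbonyl on a nitrogen on an aromatic ring. That is methylsulfonyl in place of (3,4-dichlorophenyl)carbonyl on a nitrogen on an aromatic ring. Going by the values given here, the one measured step bearing on this, a 2.7-fold lower number from compound 1 to compound 2 (0.44 log units; beyond the scatter), also removes the 3,4-dichlorophenyl and is modest. Among the compounds with values here, a step of similar size towards a lower number is expected in this assay, although no measured compound carries methylsulfonyl. The estimate for compound 3 is 7000 nM, with an expected range of 2200 nM to 20000 nM. This is an expected 2.1-fold lower number from compound 1 to compound 3 (0.33 log units; beyond the scatter).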

Compound 3, half-maximal inhibitory concentration: 25000 nM
Compound 3: middle estimate off by 3.6-fold (0.55 log units), on the low side, and the stated range ends below it.
By their numbers in this assay, from the lowest: compound 2; then compounds 1 and 3 (each within the scatter of the next).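

In this assay, methylsulfonyl in place of (3,4-dichlorophenyl)carbonyl on a nitrogen on an aromatic ring gives a 1.7-fold higher number from compound 1 to compound 3 (0.22 log units; within the scatter). The ring and both chlorines of the leaving group can therefore go without a shift beyond the scatter, so losing the 3,4-dichlorophenyl does not by itself bring the lower number seen in a 2.7-fold lower number from compound 1 to compound 2 (0.44 log units; beyond the scatter). No measurement shown here offers an explanation for this result.

Open, as far as these compounds go, is whether a free amine on this nitrogen, or a longer alkyl chain in place of the methyl on the sulfonyl, would move the number beyond the scatter of compound 1.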